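The source may hold more compounds than are shown below. What is called first, only, known or untested is meant among the compounds shown, and "the series" means these compounds.

Three members of the series have numbers in a functional assay on the whole organism (strain albino) for inhibition, with Rattus norvegicus as the target, read by paw edema, with stated times of 30 min and 5 h, at a dose of 0.28 mmol/kg by the oral route; a lower number here means less inhibition, a higher number more inhibition at the dose given (going by the name of the read-out). Compound 2 `COc1cc(-c2nnc(SCC(=O)Nc3ccc(/C(C)=N/O)cc3)n2-c2ccccc2)cc(OC)c1OC` gives 70%, compound 1 `C=CCn1c(SCC(=O)Nc2ccc(C(C)=O)cc2)nnc1-c1ccccc1` gives 63%, and compound 3 `CCn1c(SCC(=O)Nc2ccc(/C(C)=N/O)cc2)nnc1-c1cc(OC)c(OC)c(OC)c1` gives 61%. Compound 2 thus carries the highest of the three numbers, though its gaps to compound 1 and compound 3 both lie within the scatter. Going by the values given here, the only single-point step among the measured compounds, a number 9 percentage points lower from compound 2 to compound 3 (within the scatter), stayed within the scatter. Compound 4 `COc1ccc(-c2nnc(SCC(=O)Nc3ccc(/C(C)=N/O)cc3)n2-c2ccccc2)cc1OC` differs from compound 2 by hydrogen in place of methoxy on an aromatic carbon. No measured step touches the 3,4,5-trimethoxyphenyl group, so nothing shown bears directly on this change, and the one step shown was flat. A step of no more than the scatter is therefore expected, a number 2 percentage points lower from compound 2 to compound 4 (within the scatter). For compound 4 the expected value in this assay is 68%, ranging from 55% to 80%.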

Compound 4, a percentage reported as inhibition, in the whole organism at one dose (the size of the read-out at that dose, not a potency): 76%
Beside the measured number, compound 4's estimate is 8 percentage points below it; the measured number falls inside the stated range.
By their numbers in this assay, from the lowest: compounds 3, 1, 2 and 4 (each within the scatter of the next, the first and the last beyond it).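

In this assay, going by these compounds alone, the first measured change on the trimethoxyphenyl ring, 3,4,5-trimethoxyphenyl to 3,4-dimethoxyphenyl, gives a number 6 percentage points higher from compound 2 to compound 4 (within the scatter) and so stays flat. At this aromatic carbon, then, methoxy and hydrogen cannot be told apart in this read-out, at this single dose. No measurement shown offers an explanation for this step. Still open, on these data alone, is whether an amine or an ethoxy group at this carbon would also stay flat. Also open, as far as these compounds go, is whether hydrogen in place of methoxy gives the same step when ethyl replaces phenyl on the aromatic nitrogen.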